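The compounds below may be only part of what the source reports. "The series", "measured", "known", "first", "only" and "open" are said of these compounds alone.

Measured so far in a functional assay on SW480 cells (Homo sapiens) for antiproliferative activity, read by MTT assay, with a stated time of 48 h; on this read-out higher numbers stand for weaker inhibition and lower numbers for stronger inhibition:
compound 1, `CCC(CCO)n1cnc2c(Cl)nc(F)nc21`, gives 19800 nM;
compound 3, `CCCCCCC(CCO)n1cnc2c(Cl)nc(F)nc21`, gives 12900 nM.
Compound 2, `CCC(CCO)n1cnc2c(Cl)ncnc21`, reaches only the limit of this assay and gives > 50000 nM.

Compound 3 differs from compound 1 by butyl in place of hydrogen on a saturated chain carbon, three bonds along the chain from an aromatic nitrogen, and the two numbers sit close together: a 1.5-fold lower number from compound 1 to compound 3 (0.19 log units; within the scatter). The change from compound 1 to compound 2 is hydrogen in place of fluoro on an aromatic carbon; on this step the number moves an at least 2.5-fold higher number from compound 1 to compound 2 (0.40 log units; beyond the scatter), and how much further it goes is hidden by the limit of > 50000 nM in this assay, at which 1 of the 3 values shown sits.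

Compound 4, `CCCCCCC(CCO)n1cnc2c(Cl)ncnc21`, remains to be measured. It differs from compound 3 by hydrogen in place of fluoro on an aromatic carbon, the same change at the same place as from compound 1 to compound 2. Set beside an at least 2.5-fold higher number from compound 1 to compound 2 (0.40 log units; beyond the scatter), the expected step here is a 3.1-fold higher number from compound 3 to compound 4 (0.49 log units; beyond the scatter), resting on compound 2 sitting at the limit of > 50000 nM in this assay, at which 1 of the 3 values shown sits. Compound 4 is accordingly expected to give about 40000 nM in this assay. The expected range runs from 20000 nM to 100000 nM, and a fair chance remains that this assay will again report only a limit for compound 4.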

Compound 4, half-maximal inhibitory concentration: 16700 nM
The estimate for compound 4 lay 2.4-fold (0.38 log units) above the measured number; the whole stated range lies above it.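

In this assay, hydrogen in place of fluoro on the butyl-extended core gives a 1.3-fold higher number from compound 3 to compound 4 (0.11 log units; within the scatter), whereas the same change on the core of compound 1 gave a step beyond the scatter: the same change on two cores in this assay, an at least 2.5-fold higher number (0.40 log units; beyond the scatter) from compound 1 to compound 2 and a 1.3-fold higher number (0.11 log units; within the scatter) from compound 3 to compound 4; the limit leaves it open whether they differ

Read the other way, butyl in place of hydrogen gives an at least 2.9-fold lower number from compound 2 to compound 4 (0.47 log units; beyond the scatter), a step beyond the scatter, whereas the same change with fluoro present stayed within it: the same change on two cores in this assay, a 1.5-fold lower number (0.19 log units; within the scatter) from compound 1 to compound 3 and an at least 2.9-fold lower number (0.47 log units; beyond the scatter) from compound 2 to compound 4; the limit leaves it open whether they differ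

Among these compounds, compound 2 gives > 50000 nM, which is a limit and not a number, so these pairs do not establish that the size of either change depends on the core, and they show only that the step seen on one core cannot be assumed to carry over unchanged to the other.

Still open, going by these compounds, is whether the fluoro change reads the same way on a core with a longer chain or with a carboxylic acid in place of the alcohol. Also open, on these data alone, is how either core responds to an amine in place of the chloro group.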